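A few compounds are considered here, and "the series" means these few. Any claim that something is new, unique, unknown or untested is made for them only; others in the source may bear on it.

Going by the values given here, in a functional assay on MDA-MB-231 cells (Homo sapiens) for inhibition, read by MTT assay, with a stated time of 48 h (on this read-out higher numbers stand for weaker inhibition of growth and lower numbers for stronger inhibition of growth), three compounds have numbers so far. Compound 1 (`CCc1cccc(Nc2ncnc3ccc(NC(=S)NCc4ccccc4)cc23)c1`) gives 10500 nM, compound 2 (`S=C(Nc1ccccc1)Nc1ccc2ncnc(Nc3cccc(Br)c3)c2c1`) gives 10000 nM, and compound 3 (`S=C(Nc1ccc(Cl)cc1)Nc1ccc2ncnc(Nc3cccc(Br)c3)c2c1`) gives 8200 nM. Compound 3 therefore stands level with the other two, within the usual scatter of both. Compound 4 (`Oc1ccc(NC(=S)Nc2ccc3ncnc(Nc4cccc(Br)c4)c3c2)cc1`) changes a single group of compound 3: hydroxy in place of chloro on an aromatic carbon. In words, this is hydroxy in place of chloro on an aromatic carbon, para to a large group. Among the compounds with values here, the one measured step at this place is a 1.2-fold lower number from compound 2 to compound 3 (0.09 log units; within the scatter), with chloro in place of hydrogen on an aromatic carbon. Within the data shown here, that step is small, but it says nothing directly about hydroxy, since no compound with that group has a number yet. The safest expectation is therefore no change beyond the scatter. The expected step is a 1.1-fold higher number from compound 3 to compound 4 (0.04 log units; within the scatter), and its direction is not a firm call. For compound 4 the estimated value is 9000 nM, with an expected range of 4000 nM to 20000 nM.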

Compound 4, concentration for 50% growth inhibition: 17300 nM
For compound 4 the middle estimate is 1.9-fold (0.28 log units) below the measured one, within the range that was stated.
By their numbers in this assay, from the lowest: compounds 3, 2, 1 and 4 (each within the scatter of the next, the first and the last beyond it).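

In this assay, going by these compounds alone, this position now responds to the group placed on it: hydroxy in place of chloro gives a 2.1-fold higher number from compound 3 to compound 4 (0.32 log units; beyond the scatter) and is the first step here to lie beyond the scatter, though only modestly. Hydroxy in place of hydrogen gives a 1.7-fold higher number from compound 2 to compound 4 (0.24 log units; within the scatter) and stays within the scatter, so the hydroxy compound cannot be told apart from the one with hydrogen, and the clear difference is only the one between chloro and hydroxy. Nothing measured here explains that difference.

Still open, as far as these compounds go, is how other groups at this position, such as an amine, a methoxy group or a carboxylic acid, would compare with chloro and hydroxy. Also open, from the compounds shown here alone, is whether the same change would give a similar step in a compound such as compound 1, whose other parts differ.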